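The compounds below may be only part of what the source reports. "The series", "measured", "known", "first", "only" and "open" are said of these compounds alone.

Measured so far:
- compound 1, `COC(=O)Cn1c(=O)c(S(=O)(=O)c2ccc(F)cc2F)cc2cnc(Nc3ccc4[nH]ccc4c3)nc21`: 5000 nM
- compound 2, `Cn1c(=O)c(S(=O)(=O)Cc2ccc(F)cc2F)cc2cnc(Nc3ccc4[nH]ccc4c3)nc21`: 1000 nM
- compound 3, `Cn1c(=O)c(S(=O)(=O)c2ccc(F)cc2F)cc2cnc(NCc3ccc4[nH]ccc4c3)nc21`: 75000 nM

These three compounds share one core and were tested in a functional assay on K562 cells (Homo sapiens) for inhibition, read by trypan blue exclusion, with a stated time of 72 h; a higher number here means a weaker inhibitor, a lower number a stronger inhibitor. Of the three numbers, compound 2 has the lowest, and both other compounds lie beyond the usual scatter from it, so compound 2 is the strongest inhibitor here. Compound 1 comes nearest to it, and compound 3, the only one whose indole is joined to the core through an extra carbon, stands furthest away.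

Compound 4, `Cn1c(=O)c(S(=O)(=O)c2ccc([N+](=O)[O-])cc2F)cc2cnc(Nc3ccc4[nH]ccc4c3)nc21`, has not yet been measured in this assay. It differs from compound 2 in one place: 2-fluoro-4-nitrophenyl in place of 2,4-difluorobenzyl on a sulfonyl sulfur. The aromatic ring is now joined directly to the sulfonyl sulfur, and a nitro group replaces one of the fluorines.

Going by the values given here, no step between two measured compounds isolates this change, so the expectation rests on the general picture. Compound 1, which also carries an aromatic ring directly on the sulfonyl sulfur, gives a higher number than compound 2, though it differs elsewhere as well. The step of a 2.5-fold higher number from compound 2 to compound 4 (0.40 log units; beyond the scatter) is therefore expected to be modest and toward a higher number, perhaps no further than the scatter. Compound 4 is estimated at 2500 nM, with a range from 800 nM to 8000 nM.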

Compound 4, half-maximal inhibitory concentration: 200 nM
The estimate for compound 4 lay 13-fold (1.10 log units) above the measured number, outside the stated range (below it).
By their numbers in this assay, from the lowest: compound 4; then compound 2; then compound 1; then compound 3.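

In this assay, putting 2-fluoro-4-nitrophenyl in place of 2,4-difluorobenzyl on a sulfonyl sulfur gives a 5.0-fold lower number from compound 2 to compound 4 (0.70 log units; beyond the scatter) and leaves compound 4 with the lowest number of the four compounds. Going by these compounds alone, this shows that the position accepts a substantial change and that inhibition in these cells can improve there, which the earlier compounds could not show because no step among them isolated this site. The swap makes two changes at once, turning a benzyl group into a phenyl group on the sulfur and bringing in a nitro group where a fluorine stood, and nothing available here explains the gain.

Within the data shown here, the single step cannot say how much of the gain belongs to each of these two changes, and 2-fluoro-4-nitrobenzyl on the same sulfur would help to pull them apart. On these data alone, it also remains open whether the nitro group itself is needed, or whether a nitrile or an amine in its place on the same ring would give a similarly low number.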